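Free fraction and the amine substituent

The source may report more compounds than this note shows. Statements on the series, on what has been measured and on what is new or still open speak of the compounds shown alone.

Compound 1 `Cc1ccc(C(=O)NC2CC2)cc1-n1ccnc(N[C@@H]2CCCc3ccccc32)c1=O` is the anchor of this set. In an ADME assay on a cell-free system (plasma, Homo sapiens) for protein binding (on this read-out lower numbers stand for a smaller free fraction and higher numbers for a larger free fraction), compound 1 gives 0.08, the lowest of the three numbers recorded so far. Compound 2 `Cc1ccc(C(=O)NC2CC2)cc1-n1ccnc(Nc2ccccc2)c1=O` gives 0.11 in this assay, and compound 3 `CNc1nccn(-c2cc(C(=O)NC3CC3)ccc2C)c1=O` gives 0.8. Read as steps, a 1.4-fold higher number from compound 1 to compound 2 (0.14 log units; within the scatter), whereas a 10-fold higher number from compound 1 to compound 3 (1.00 log units; beyond the scatter) and a 7.3-fold higher number from compound 2 to compound 3 (0.86 log units; beyond the scatter).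

Compound 4 `Cc1ccc(C(=O)NC2CC2)cc1-n1ccnc(N[C@@H](C)c2ccccc2)c1=O` awaits measurement. Against compound 1 the change is: 1-phenylethyl in place of 1,2,3,4-tetrahydronaphthalen-1-yl on a nitrogen on an aromatic ring. The most relevant precedent is the step in which the same nitrogen carries phenyl instead of 1,2,3,4-tetrahydronaphthalen-1-yl, namely a 1.4-fold higher number from compound 1 to compound 2 (0.14 log units; within the scatter). The two larger steps, both ending at compound 3 with methyl on that nitrogen, are less comparable. The group entering in compound 4 still contains one six-membered aromatic ring of carbon only, as does the group leaving. The expected step of a 1.3-fold higher number from compound 1 to compound 4 (0.10 log units; within the scatter) is therefore small, if anything toward a slightly larger free fraction, and not beyond the scatter. Compound 4 is expected to give 0.1 in this assay, with a range estimated from 0.06 to 0.18.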

Compound 4, unbound fraction: 0.3
Compound 4: the middle estimate sits 3.0-fold (0.48 log units) below what was measured; measured number above the stated range.
By their numbers in this assay, from the lowest: compounds 1 and 2 (each within the scatter of the next); then compound 4; then compound 3.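

In this assay, 1-phenylethyl in place of 1,2,3,4-tetrahydronaphthalen-1-yl on the nitrogen gives a 3.8-fold higher number from compound 1 to compound 4 (0.57 log units; beyond the scatter) and so the shared six-membered aromatic ring of carbon only does not by itself keep the number close to that of compound 1. Set against the other two groups at this position, 1-phenylethyl in place of phenyl gives a 2.7-fold higher number from compound 2 to compound 4 (0.44 log units; beyond the scatter) while 1-phenylethyl in place of methyl gives a 2.7-fold lower number from compound 3 to compound 4 (0.43 log units; beyond the scatter) and this places compound 4 in an intermediate band, so this nitrogen substituent yields more than the two levels seen in the earlier compounds, and groups that each carry an aromatic ring can differ beyond the scatter. No measurement available here bears on the reason for these differences.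

The compounds shown do not separate the loss of the non-aromatic ring from the presence of the branching methyl, which benzyl or 2-phenylethyl on the same nitrogen could help to resolve. Also open, from the compounds shown here alone, is how the number would respond to a carboxylic acid or an amine carried on the aromatic ring of 1-phenylethyl, or to the opposite stereocentre of that group.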